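Phenyl in place of cyclohexyl on the ring nitrogen

The source may hold more compounds than are shown below. What is called first, only, known or untested is meant among the compounds shown, and "the series" means these compounds.

Of the compounds shown here, two have been measured. Compound 1 `CN1C(=S)N(c2ccccc2)C(=O)/C1=C\c1ccc(N(C)CCCO)cc1` and compound 2 `COc1cc(N(C)CCCO)ccc1/C=C1\C(=O)N(C2CCCCC2)C(=S)N1C` share a common core and differ in two places at once. In an assay on isolated protein for inhibition of NADPH oxidase 4 (Homo sapiens), read by chemiluminescence, in the presence of a further agent that is not named here (on this read-out lower numbers stand for stronger inhibition and higher numbers for weaker inhibition), compound 1 gives 3390 nM. In this assay compound 2 gives 2170 nM. Set against compound 1, compound 2 stands within the usual scatter of repeated measurements, so the two numbers cannot be told apart on this evidence.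

Compound 3 `COc1cc(N(C)CCCO)ccc1/C=C1\C(=O)N(c2ccccc2)C(=S)N1C` is derived from compound 2 by a single change: phenyl in place of cyclohexyl on an amide-type nitrogen in a ring. Going by the values given here, no measured pair isolates this change. Compound 1 also carries a phenyl on that amide-type nitrogen, but it lacks the methoxy group of compound 3, so its value cannot serve as a direct guide. Among the compounds with values here, with no step of this kind on record and both measured numbers lying within the scatter of each other, no shift beyond the scatter is expected in this assay. Compound 3 is therefore estimated at 2700 nM, with a range from 1000 nM to 7000 nM. The expected step is a 1.2-fold higher number from compound 2 to compound 3 (0.09 log units; within the scatter).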

Compound 3, half-maximal inhibitory concentration: 2480 nM
Compound 3: the middle estimate sits 1.1-fold (0.04 log units) above what was measured; measured number inside the range.
By their numbers in this assay, from the lowest: compounds 2, 3 and 1 (each within the scatter of the next).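

In this assay, the amide-type nitrogen in a ring now has a step of its own, since phenyl in place of cyclohexyl gives a 1.1-fold higher number from compound 2 to compound 3 (0.06 log units; within the scatter) with the rest of the molecule held fixed; an aromatic and a non-aromatic six-membered carbon ring of equal heavy-atom count therefore cannot be told apart at this position. Going by these compounds alone, the same compound also isolates a second change for the first time, as methoxy in place of hydrogen on an aromatic carbon gives a 1.4-fold lower number from compound 1 to compound 3 (0.14 log units; within the scatter), so neither single change moves the number beyond the scatter. Nothing at hand explains why these two changes leave the numbers so close.

The compounds shown leave open whether any group on the amide-type nitrogen can separate itself from phenyl and cyclohexyl, for instance a benzyl group, a pyridine ring or a small methyl group. They also leave open whether a larger change elsewhere, such as an amine or a carboxylic acid in place of the hydroxyl at the end of the chain, would produce a step beyond the scatter in this assay at all.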